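The compounds below may be only part of what the source reports. "The series", "measured", "known", "first", "only" and "open" are said of these compounds alone.

Measured so far in a functional assay on MCF7 cells (Homo sapiens) for antiproliferative activity, read by CCK-8 assay, with a stated time of 72 h; a lower number here means a stronger inhibitor, a higher number a weaker inhibitor:
- compound 1 `Cc1cc(Nc2cc(N3CCN(C)CC3)nc(Nc3ccc([N+](=O)[O-])cc3)n2)n[nH]1`, 424 nM
- compound 2 `Cc1cc(Nc2cc(N3CCN(C)CC3)nc(Nc3ccc(Cl)cc3)n2)n[nH]1`, 840 nM
- compound 3 `COc1cccc(Nc2nc(Nc3cc(C)[nH]n3)cc(N3CCN(C)CC3)n2)c1`, 933 nM

Compound 3 sits at the high end of the three numbers: a 2.2-fold higher number from compound 1 to compound 3 (0.34 log units; beyond the scatter), and a 1.1-fold higher number from compound 2 to compound 3 (0.05 log units; within the scatter). The gap to compound 2 is thus within the scatter, only the gap to compound 1 is beyond it.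

Compound 4 `Cc1cc(Nc2cc(N3CCN(C)CC3)nc(Nc3ccc(C#N)cc3)n2)n[nH]1` has not been measured. It differs from compound 3 in one place: 4-cyanophenyl in place of 3-methoxyphenyl on a nitrogen on an aromatic ring. Within the data shown here, two measured steps bear on this exchange, since both replace a phenyl carrying a single group for the 3-methoxyphenyl of compound 3: a 2.2-fold higher number from compound 1 to compound 3 (0.34 log units; beyond the scatter) and a 1.1-fold higher number from compound 2 to compound 3 (0.05 log units; within the scatter). Read in the reverse direction, returning to a phenyl with one group lowered the number by a within-scatter to modest amount. Among the measured compounds shown here, the 4-cyanophenyl of compound 4 has no direct precedent among the three, so the expected step is a modest fall at most, estimated as a 1.7-fold lower number from compound 3 to compound 4 (0.23 log units; within the scatter). Compound 4 is therefore expected to give about 550 nM in this assay, with a range of 250 nM to 1200 nM.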

Compound 4, half-maximal inhibitory concentration: 372 nM
Compound 4: middle estimate off by 1.5-fold (0.17 log units), on the high side, within the range that was stated.
By their numbers in this assay, from the lowest: compounds 4, 1, 2 and 3 (each within the scatter of the next, the first and the last beyond it).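

In this assay, exchange on the aromatic nitrogen now gives a step beyond the scatter from the 3-methoxyphenyl group to the 4-cyanophenyl group (a 2.5-fold lower number from compound 3 to compound 4 (0.40 log units; beyond the scatter)), and cyano in place of chloro on an aromatic carbon does the same (a 2.3-fold lower number from compound 2 to compound 4 (0.35 log units; beyond the scatter)), whereas nitro and chloro were not separated by more than the scatter. Swapping the nitro group for the cyano group gives no change that can be read (a 1.1-fold lower number from compound 1 to compound 4 (0.06 log units; within the scatter)), so these two groups cannot be told apart here. No measurement is available that explains these differences.

Still open, going by these compounds, is how a carboxylic acid, an amide or an amine in place of the cyano would compare in this assay. On these data alone, an unsubstituted phenyl as a reference point also remains open.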